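The compounds below may be only part of what the source reports. "The series", "measured", "known", "first", "only" and "open" are said of these compounds alone.

Measured in a functional assay on U-373MG ATCC cells for inhibition, with U373 MG (Homo sapiens) as the target, read by MTT assay, with a stated time of 7 days; on this read-out higher numbers stand for weaker inhibition of growth and lower numbers for stronger inhibition of growth:

Compound 1 `NC(=O)c1ncn2c(=O)n(Cc3ccccc3)nnc12`: > 50000 nM
Compound 2 `NC(=O)c1ncn2c(=O)n(Cc3cccs3)nnc12`: > 50000 nM
Compound 3 `NC(=O)c1ncn2c(=O)n(Cc3c[nH]nn3)nnc12`: > 50000 nM

All three entries are limits and not numbers, so compound 1 has no exact place on the scale. Compound 4 `C[C@@H](c1ccccc1)n1nnc2c(C(N)=O)ncn2c1=O` is compound 1 with one change: methyl in place of hydrogen on a saturated chain carbon bound to an aromatic carbon and an aromatic nitrogen. Two measured steps start from compound 1: a step that the two limits leave unreadable from compound 1 to compound 2 and a step that the two limits leave unreadable from compound 1 to compound 3. Both replace the phenyl rather than this hydrogen, and neither has a size. Going by the values given here, the only guide is the limit of > 50000 nM in this assay, at which 3 of the 3 values shown sit, so compound 4 is expected to stay near that limit. No step beyond the scatter is expected, and the estimated step is a number no higher from compound 1 to compound 4 (the limit leaves the size open). For compound 4 the estimated value is 50000 nM, with an expected range of 25000 nM to 100000 nM.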

Compound 4, concentration for 50% growth inhibition: > 50000 nM
Compound 4: a limit, no number; the forecaster's own chance of this, stated with the estimate: 85%; the middle value sits exactly at the limit.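

Compound 1 and compound 4 both give limits, not numbers, in this assay, so the step between them cannot be read. The compounds shown leave open whether methyl in place of hydrogen changes growth inhibition at all.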